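The source may report more compounds than this note shows. Statements on the series, on what has been measured and on what is new or still open speak of the compounds shown alone.

Measured compounds:
compound 1 `Fc1ccc(-c2ccc3c(NCCCNCc4ccco4)ccnc3c2)cc1`, 32000 nM
compound 2 `COc1cccc(CNCCCNc2ccnc3cc(-c4ccc(F)cc4)ccc23)c1O`, 32000 nM
compound 3 `COc1ccc(F)cc1CNCCCNc1ccnc2cc(-c3ccc(F)cc3)ccc12`, 32000 nM

In a physicochemical assay for solubility, with a stated time of 18 h, at pH 7.4 (on this read-out higher numbers stand for higher solubility and lower numbers for lower solubility), compound 2 gives 32000 nM and stands level with compound 1 and compound 3. The three measured steps, no change at the digits printed from compound 1 to compound 2 (within the scatter), no change at the digits printed from compound 1 to compound 3 (within the scatter) and no change at the digits printed from compound 2 to compound 3 (within the scatter), all exchange the group on the saturated chain carbon bound to the amine nitrogen and all stay within the scatter.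

Compound 4 `COc1ccc(Oc2ccc3c(NCCCNCc4cccc(OC)c4O)ccnc3c2)cc1` differs from compound 2 elsewhere: 4-methoxyphenoxy in place of 4-fluorophenyl on an aromatic carbon. Going by the values given here, none of the measured steps touches this position, so they give no direct precedent for the size or direction of the change; what they show is that the shared core, with its chain, has so far kept the same value whatever was placed on the chain. Among the compounds with values here, with no precedent at the aromatic carbon, the expected step of a 1.3-fold lower number from compound 2 to compound 4 (0.11 log units; within the scatter) is set at none beyond the scatter. On that basis compound 4 is estimated at 25000 nM, with a range from 8000 nM to 64000 nM in this assay.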

Compound 4, solubility: 14500 nM
For compound 4 the middle estimate is 1.7-fold (0.24 log units) above the measured one; low and high end bracket the measured number.
By their numbers in this assay, from the lowest: compound 4; then compounds 1, 2 and 3 (each within the scatter of the next).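

With 4-methoxyphenoxy in place of 4-fluorophenyl on the aromatic carbon, this assay shows a 2.2-fold lower number from compound 2 to compound 4 (0.34 log units; beyond the scatter) and this is the only step among the compounds shown that lies beyond the scatter. Going by these compounds alone, the three exchanges on the chain carbon had left the number unmoved, so this aromatic carbon is the first place where a change of group goes with a lower number, though only modestly. No measurement shown bears on why the number moves at this position.

Still open, from the compounds shown here alone, is whether the lower number goes with the oxygen link or with the methoxy group, which a 4-fluorophenoxy or an unsubstituted phenoxy group at this carbon would help to separate. Also open, going by these compounds, is whether the same exchange would give a similar step with the chain groups of compound 1 and compound 3.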